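Carbamate terminus variation, compound 2 to compound 3

This account rests on a few compounds, and the source may have more. Where it says the series, first, only, none or still open, it means among the compounds named here.

Compound 1 `Cc1nc(S(C)(=O)=O)ccc1Oc1ncnc(OC2CCN(C(=O)OC(C)C)CC2)c1F` gives 142 nM in a functional assay on isolated protein for inhibition of Glucose-dependent insulinotropic receptor (Rattus norvegicus), read by HTRF and cAMP accumulation; on this read-out lower numbers stand for an effect already at smaller amounts and higher numbers for an effect only at larger amounts of compound.
Compound 2 `Cc1nc(S(C)(=O)=O)ccc1Oc1ncnc(OC2CCN(C(=O)OC3(C(F)(F)F)CCC3)CC2)c1F` gives 63.3 nM in this assay.

In this assay compound 2 holds the lowest of the two numbers; compound 1 is its nearest neighbour, separated by a 2.2-fold lower number from compound 1 to compound 2 (0.35 log units; beyond the scatter).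

Compound 3 `Cc1nc(S(C)(=O)=O)ccc1Oc1ncnc(OC2CCN(C(=O)SC(C)(C)C)CC2)c1F` differs from compound 2 by a group of 5 heavy atoms (4 carbon, 1 sulfur; no ring) in place of a group of 9 heavy atoms (5 carbon, 1 oxygen, 3 fluorine; one four-membered non-aromatic ring of carbon only), on a carbonyl carbon. Among the measured compounds shown here, no measured step involves the sulfur. For the measured compounds named here, the only step that bears on it is the change of the same group, a 2.2-fold lower number from compound 1 to compound 2 (0.35 log units; beyond the scatter), which was modest. A modest move back toward the number of compound 1 is therefore expected, a 1.6-fold higher number from compound 2 to compound 3 (0.20 log units; within the scatter). For compound 3 the estimate is 100 nM, with a range of 40 nM to 250 nM.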

Compound 3, half-maximal effective concentration: 30.7 nM
For compound 3 the middle estimate is 3.3-fold (0.51 log units) above the measured one, and the stated range ends above it.
By their numbers in this assay, from the lowest: compound 3; then compound 2; then compound 1.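

The (tert-butyl)sulfanyl group on the carbonyl carbon gives a 2.1-fold lower number from compound 2 to compound 3 (0.31 log units; beyond the scatter) and a 4.6-fold lower number from compound 1 to compound 3 (0.67 log units; beyond the scatter) in this assay, both beyond the scatter. At this position, then, neither the ring nor the fluorines of compound 2 are required for the lowest number of the three, and a sulfur bound to the carbonyl carbon is accepted. Nothing measured here accounts for either step.

Compound 3 changes the attached atom and the alkyl group together, so a tert-butoxy group would be needed to separate the sulfur from the tert-butyl. From the compounds shown here alone, how an amine on the same carbonyl carbon would read remains open.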